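The source may report more compounds than this note shows. Statements on the series, on what has been measured and on what is new or still open speak of the compounds shown alone.

The measured compounds:
Compound 1 `Fc1ccc(C(SCCNC2CCN(Cc3ccc(Cl)cc3)CC2)c2ccc(F)cc2)cc1` gives 39.6 nM in an assay on membranes from striatum (strain Sprague-Dawley) for displacement of a labelled ligand from sodium-dependent dopamine transporter (Rattus norvegicus), read by scintillation counting, with a stated time of 120 min; on this read-out lower numbers stand for stronger inhibition and higher numbers for weaker inhibition.
Compound 2 `Fc1ccc(C(SCCNC2CCN(Cc3cc4ccccc4o3)CC2)c2ccc(F)cc2)cc1` gives 120 nM in this assay.

For the measured compounds named here, compound 2 holds the highest of the two numbers so far in this assay. Its nearest neighbour is compound 1. Going by the values given here, the single step between them, a 3.0-fold higher number from compound 1 to compound 2 (0.48 log units; beyond the scatter), lies beyond the scatter and exchanges one aromatic group for another at the same place.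

Compound 3 `CC(C)(C)CN1CCC(NCCSC(c2ccc(F)cc2)c2ccc(F)cc2)CC1` has not yet been measured. Its difference from compound 2 is tert-butyl in place of 1-benzofuran-2-yl on a saturated chain carbon bound to an amine nitrogen in a ring. Among the compounds with values here, only one measured step touches this place, and it is the one just described; no measured step removes the ring at this place altogether, so the bearing is indirect. The account expects the number to move further towards weaker inhibition, because a 3.0-fold higher number from compound 1 to compound 2 (0.48 log units; beyond the scatter) already ran in that direction when the group at this place changed, and the step is expected to be about a 2.5-fold higher number from compound 2 to compound 3 (0.40 log units; beyond the scatter). Compound 3 is therefore estimated at 300 nM, with a range from 80 nM to 1200 nM.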

Compound 3, inhibition constant: 279 nM
For compound 3 the middle estimate is 1.1-fold (0.03 log units) above the measured one; low and high end bracket the measured number.
By their numbers in this assay, from the lowest: compound 1; then compound 2; then compound 3.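

Replacing the aromatic group with one that has no ring at all, tert-butyl in place of 1-benzofuran-2-yl on a saturated chain carbon bound to an amine nitrogen in a ring, gives a 2.3-fold higher number from compound 2 to compound 3 (0.37 log units; beyond the scatter) and thus extends the trend that began with the exchange of one aromatic group for another. Measured against the 4-chlorophenyl group, the same replacement gives a 7.0-fold higher number from compound 1 to compound 3 (0.85 log units; beyond the scatter), so among these three compounds both groups with an aromatic ring give lower numbers than tert-butyl in this assay, and none of the three goes against this, although compound 3 still gives a finite reading of 279 nM without any ring at this place. No evidence is available to explain why the numbers move this way.

The compounds shown leave open whether an aromatic ring or simply a ring matters here, a question that a cyclohexyl group at this place could help to separate. They also do not show how a plain phenyl group, a pyridine ring, a longer alkyl chain or a group carrying an amine or a carboxylic acid would compare at this place.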